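This account rests on a few compounds, and the source may have more. Where it says the series, first, only, none or still open, it means among the compounds named here.

Measured compounds in a functional assay on the whole organism (strain Albino Swiss CD1) with Mus musculus as the target, in the maximal electroshock model; a lower number here means that less compound is needed, a higher number that more compound is needed for the effect:
compound 1 `CC(C(=O)NCc1ccccc1Cl)N1C(=O)CCC1=O` gives 74.5 mg/kg
compound 2 `CCC(C(=O)NCc1ccc(F)cc1)N1C(=O)CCC1=O` gives "not determined" (no result reported)
compound 3 `CC1CC(=O)N(C(C)C(=O)NCc2ccccc2)C1=O` gives 106 mg/kg

Compound 3 holds the highest of the two numbers available. Its nearest neighbour is compound 1, whose number is lower, but that gap lies within the scatter, so no order between the two can be read. Compound 2 contributes no number.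

Compound 4 `CC1CC(=O)N(C(C)C(=O)NCc2ccccc2Cl)C1=O` differs from compound 3 by chloro in place of hydrogen on an aromatic carbon. Going by the values given here, no pair of measured compounds isolates this change; compound 1 carries the chloro group on a different core, and its number and that of compound 3 sit within the scatter of each other. Compound 4 is therefore expected to move from compound 3 by no more than the scatter, a 1.3-fold lower number from compound 3 to compound 4 (0.12 log units; within the scatter). The estimate for compound 4 in this assay is 80 mg/kg, expected between 45 mg/kg and 160 mg/kg.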

Compound 4, dose for half-maximal effect: 85.9 mg/kg
The estimate for compound 4 lay 1.1-fold (0.03 log units) below the measured number; low and high end bracket the measured number.
By their numbers in this assay, from the lowest: compounds 1, 4 and 3 (each within the scatter of the next).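

In this assay chloro in place of hydrogen on an aromatic carbon, ortho to a large group, now has a step of its own: a 1.2-fold lower number from compound 3 to compound 4 (0.09 log units; within the scatter) and so no order can be read. Methyl in place of hydrogen on a saturated ring carbon, seen with the 2-chlorophenyl group present, gives a 1.2-fold higher number from compound 1 to compound 4 (0.06 log units; within the scatter) and likewise allows no order. Nothing available bears on the reason for these two results. Still open, from the compounds shown here alone, is whether an amine at this aromatic carbon, or a longer chain in place of the ring methyl, would give a step beyond the scatter.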